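This account rests on a few compounds, and the source may have more. Where it says the series, first, only, none or still open, it means among the compounds named here.

Working notes on the series. For the measured compounds named here, in a functional assay on cells for positive allosteric modulation, with A2780/Taxol (Homo sapiens) as the target, read by MTT assay, with a stated time of 48 h, tested at 10 uM (a lower number here means a stronger inhibitor, a higher number a weaker inhibitor), compound 1 (`CCOc1ccc2c(C)cc(=O)oc2c1COC(=O)c1cccc(N(C)C)c1`) gives 17.7 nM, the lowest of the two numbers so far. Compound 2 (`CCOc1ccc2c(C)cc(=O)oc2c1COC(=O)c1cc(OC)c(OC)cc1OC`) gives 83.8 nM, a gap beyond the scatter. Compound 3 (`CCOc1ccc2c(C)cc(=O)oc2c1COC(=O)/C=C/c1ccccc1`) is not yet measured. It carries 2-phenylethenyl in place of 3-(dimethylamino)phenyl on a carbonyl carbon. Going by the values given here, no measured pair differs in one place, so the step size is poorly constrained. A step to a higher number, beyond the scatter, is expected in this assay: a 2.8-fold higher number from compound 1 to compound 3 (0.45 log units; beyond the scatter). The estimated value for compound 3 is 50 nM, with an expected range of 12 nM to 200 nM.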

Compound 3, half-maximal inhibitory concentration: 40.8 nM
For compound 3 the middle estimate is 1.2-fold (0.09 log units) above the measured one; the measured number falls inside the stated range.
By their numbers in this assay, from the lowest: compound 1; then compound 3; then compound 2.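

For the compounds shown here, replacing 3-(dimethylamino)phenyl with 2-phenylethenyl on a carbonyl carbon gives a 2.3-fold higher number from compound 1 to compound 3 (0.36 log units; beyond the scatter) in this assay, the only single-place step so far. The step is modest, so this position keeps activity in this assay without the nitrogen of the leaving group and with a double bond outside aromatic rings. No available measurement accounts for the size of this step. Unsubstituted phenyl and 2-phenylethyl on the same carbonyl carbon remain open, so the separate contributions of the dimethylamino group and the double bond cannot be read.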